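From carboxy to methoxy: expecting a lower number

The source may report more compounds than this note shows. Statements on the series, on what has been measured and on what is new or still open speak of the compounds shown alone.

In a physicochemical assay for solubility, read by spectrophotometry, in phosphate buffer, with a stated time of 18 h, at pH 7.4 (on this read-out lower numbers stand for lower solubility and higher numbers for higher solubility), three compounds that differ at one place on a shared core have been measured. Compound 1 `CCc1ccc(-c2nc3c(c(C)nn3-c3ccccc3)c(-c3ccccc3F)c2C#N)cc1`, which carries fluoro there, gives 1700 nM. Compound 2 `CCc1ccc(-c2nc3c(c(C)nn3-c3ccccc3)c(-c3ccccc3C)c2C#N)cc1`, which carries methyl, gives 6000 nM. Compound 3 `CCc1ccc(-c2nc3c(c(C)nn3-c3ccccc3)c(-c3ccccc3C(=O)O)c2C#N)cc1`, which carries carboxy, gives 33000 nM, the highest of the three numbers.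

The next compound is compound 4 `CCc1ccc(-c2nc3c(c(C)nn3-c3ccccc3)c(-c3ccccc3OC)c2C#N)cc1`, with methoxy in place of carboxy on an aromatic carbon. For the measured compounds named here, no measured compound carries methoxy, so the evidence is indirect. The closest guides are the two steps that introduce carboxy, a 19-fold higher number from compound 1 to compound 3 (1.29 log units; beyond the scatter), which is large, and a 5.5-fold higher number from compound 2 to compound 3 (0.74 log units; beyond the scatter), which is modest. The step of a 3.5-fold higher number from compound 1 to compound 2 (0.55 log units; beyond the scatter) shows that the two compounds without carboxy also differ from each other. Compound 4 also lacks carboxy, so in this assay a modest to large fall is expected, reversing those two steps. The expected change is an 8.3-fold lower number from compound 3 to compound 4 (0.92 log units; beyond the scatter). Compound 4 is estimated at 4000 nM, with an expected range of 1500 nM to 11000 nM.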

Compound 4, solubility: 7800 nM
Estimate against measurement, compound 4: 2.0-fold (0.29 log units) below; the measured number falls inside the stated range.
By their numbers in this assay, from the lowest: compound 1; then compounds 2 and 4 (each within the scatter of the next); then compound 3.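

In this assay, with a third group without carboxy now at this position on the aromatic ring, carboxy still gives the highest number, with a 4.2-fold lower number from compound 3 to compound 4 (0.63 log units; beyond the scatter) as the new step. The groups without carboxy do not all behave alike: a 1.3-fold higher number from compound 2 to compound 4 (0.11 log units; within the scatter) leaves methoxy and methyl unseparated, while a 4.6-fold higher number from compound 1 to compound 4 (0.66 log units; beyond the scatter) sets methoxy clearly apart from fluoro, and compound 1 keeps the lowest number of the four. Nothing measured here explains these differences.

Open, on these data alone, is whether an amine or an ethoxy group at this position would fall with methyl and methoxy or come closer to carboxy. Also open, as far as these compounds go, is whether this order of groups would hold if the ethyl group elsewhere on the shared core were replaced by a longer chain.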